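The source may report more compounds than this note shows. Statements on the series, on what has been measured and on what is new or still open speak of the compounds shown alone.

Compound 1 `CCCCCC(CCO)n1cnc2c(N(C)C)ncnc21`: > 50000 nM (a limit)
Compound 2 `CCCCCC(CCO)n1cnc2c(N)ncnc21`: > 50000 nM (a limit)
Compound 3 `CCCCCC(CCO)n1cnc2c(N)nc(Cl)nc21`: > 50000 nM (a limit)

These readings come from a functional assay on SW480 cells (Homo sapiens) for antiproliferative activity, read by MTT assay, with a stated time of 48 h; a higher number here means a weaker inhibitor, a lower number a stronger inhibitor. Compound 2 has no exact number and stands with the others at the limit of > 50000 nM in this assay, at which 3 of the 3 values shown sit. Compound 4 `CCCCCCC(CCO)n1cnc2c(N)ncnc21` differs from compound 2 by one change: methyl in place of hydrogen on a saturated chain carbon, six bonds along the chain from an aromatic nitrogen. Two measured steps are available: a step that the two limits leave unreadable from compound 1 to compound 2, and a step that the two limits leave unreadable from compound 2 to compound 3. Neither step alters the chain, and neither has a readable size to carry over. The expectation rests on compound 2, whose > 50000 nM is a limit. No clear shift in either direction is therefore expected in this assay, and another limit is the likeliest report. The expected step is a step that the limit leaves unreadable from compound 2 to compound 4. For compound 4 the estimated value is 60000 nM, with an expected range from 25000 nM to 150000 nM.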

Compound 4, half-maximal inhibitory concentration: > 50000 nM
Compound 4 ended at the assay's limit (the forecaster's own chance of this, stated with the estimate: 75%); the middle value does not contradict the limit.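

Compound 2 and compound 4 both stand at a limit rather than an exact number, and the step between them cannot be read: the limit of > 50000 nM in this assay, at which 4 of the 4 values shown sit.

On these data alone, whether any change to the chain or the shared core can give an exact value in this assay stays open.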